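A few compounds are considered here, and "the series" means these few. Any claim that something is new, unique, unknown or untested is made for them only; others in the source may bear on it.

Measured compounds:
compound 1 `CCCCc1sc(-c2ccc(OCC3CCCN(CC)C3)cc2)nc1-c1ccc(Oc2ccc(Cl)cc2)cc1` — 660 nM
compound 2 `CCCCc1sc(Nc2ccc(OCCCN(CC)CC)cc2)nc1-c1ccc(Oc2ccc(Cl)cc2)cc1` — 550 nM

In an assay on isolated protein for antagonist activity at advanced glycosylation end product-specific receptor (Homo sapiens), read by ELISA, with a stated time of 60 min (on this read-out higher numbers stand for weaker inhibition and lower numbers for stronger inhibition), compound 1 gives 660 nM, the higher of the two numbers recorded, while compound 2 gives 550 nM; the gap between them lies within the scatter, so the two read as equivalent. Compound 3 `CCCCc1sc(-c2ccc(OCCCN(CC)CC)cc2)nc1-c1ccc(Oc2ccc(Cl)cc2)cc1` is the next member and has not yet been measured. It differs from compound 1 in one place: 2-(diethylamino)ethyl in place of 1-ethylpiperidin-3-yl on a saturated chain carbon bound to an oxygen on an aromatic ring. Compound 2 already carries the 3-(diethylamino)propyl chain on its aryl oxygen, though attached to the core through an amino link rather than directly, and its value sits alongside that of compound 1. For the measured compounds named here, no measured pair isolates this change on the directly linked core, so the step is judged from compound 1 alone. Compound 3 is expected to land close to compound 1, with a step of a 1.1-fold lower number from compound 1 to compound 3 (0.04 log units; within the scatter) that stays within the scatter. Compound 3 is thus estimated at 600 nM, between 250 nM and 1500 nM.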

Compound 3, half-maximal inhibitory concentration: 1720 nM
Compound 3: middle estimate off by 2.9-fold (0.46 log units), on the low side; the measured number lies above the stated range.
By their numbers in this assay, from the lowest: compounds 2 and 1 (each within the scatter of the next); then compound 3.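

In this assay, the amine-bearing group on the aryl oxygen turns out not to be interchangeable: opening the 1-ethylpiperidin-3-yl ring to 2-(diethylamino)ethyl gives a 2.6-fold higher number from compound 1 to compound 3 (0.42 log units; beyond the scatter), although the group changes little in size and the count of hydrogen-bond acceptors stays the same. The same 3-(diethylamino)propyl chain does not give a weak number in every setting, since compound 2, which carries it on an amino link, reads 550 nM against 1720 nM for compound 3. No measurement shown explains the step.

Going by these compounds, whether the ring itself matters, or only the way the nitrogen is held, remains open for this single pair. A 1-ethylpyrrolidin-3-yl ring or a dimethylamino end group at this place would test that, as would the 1-ethylpiperidin-3-yl group on the amino-linked core.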